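The compounds below may be only part of what the source reports. "The series", "measured", "known", "first", "only" and "open" are said of these compounds alone.

Measured compounds:
Compound 2, `NC(=O)CCCN(Cc1cccc(C(=O)O)c1)C[C@H]1O[C@@H](n2cnc3c(N)ncnc32)[C@H](O)[C@@H]1O`: in an assay on cells for inhibition of Nicotinamide N-methyltransferase (Homo sapiens), with stated times of 10 min and 30 min (on this read-out higher numbers stand for weaker inhibition and lower numbers for stronger inhibition), compound 2 gives > 250000 nM, which is a limit of the assay and not a number.
Compound 1, `COC(=O)c1cccc(CN(CCCCC(N)=O)C[C@H]2O[C@@H](n3cnc4c(N)ncnc43)[C@H](O)[C@@H]2O)c1`: in this assay compound 1 gives > 250000 nM, again only a limit.

Within the data shown here, compound 2 thus stands at the limit of this assay, and nothing places it relative to compound 1, whose value is the same limit. the limit of > 250000 nM in this assay, at which 2 of the 2 values shown sit, sums up what is known: both values shown are limits, and no step between measured compounds can be counted.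

Compound 3, `NC(=O)CCCCN(Cc1cccc(C(=O)O)c1)C[C@H]1O[C@@H](n2cnc3c(N)ncnc32)[C@H](O)[C@@H]1O`, differs from compound 2 in one place: carbamoylmethyl in place of carbamoyl on a saturated chain carbon, three bonds along the chain from an amine nitrogen. Compound 1 carries a chain of the same length on the amine nitrogen and did not reach a number either.

Among the measured compounds shown here, with no step measured and every value at the limit, no size of step can be read from the data. The step from compound 2 to compound 3 is expected to be none beyond the scatter, a number no higher from compound 2 to compound 3 (the limit leaves the size open). Compound 3 is therefore expected to sit at 250000 nM in this assay, within a range of 100000 nM to 600000 nM, and most probably to be reported once more only as a limit.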

Compound 3, half-maximal inhibitory concentration: > 250000 nM
Compound 3 was reported as a limit; the forecaster's own chance of this, stated with the estimate: 85%; the middle value sits exactly at the limit.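

In this assay compound 3 gives > 250000 nM, again only a limit of the assay and not a number. Among these compounds, no step from compound 1 or compound 2 to compound 3 can be read: the limit of > 250000 nM in this assay, at which 3 of the 3 values shown sit. The compounds shown leave open whether either the carbamoyl chain change or the methyl on the oxygen makes any difference to inhibition.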